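Amino position swap on the anilino ring of compound 1

This account rests on a few compounds, and the source may have more. Where it says the series, first, only, none or still open, it means among the compounds named here.

Working notes on the series. Compound 1 `Nc1ccc(Nc2c(C(=O)NCc3ccc(F)cc3)nc(Br)c3cccnc23)cc1` is assessed in a functional assay on HCT-116 cells (Homo sapiens) for cytotoxicity, read by MTT assay, with a stated time of 72 h; a higher number here means a weaker inhibitor, a lower number a stronger inhibitor. In this assay compound 1 gives 7000 nM. For the measured compounds named here, the only other measured member is compound 2 `CS(=O)(=O)NCCCCCCN(c1nc(C(=O)NCc2ccc(F)cc2)c(O)c2ncccc12)S(C)(=O)=O`, which carries a different substitution pattern on the shared core; in this assay compound 2 gives 4000 nM. Going by the values given here, the two numbers lie within the usual scatter of each other, so on the numbers at hand compound 1 and compound 2 cannot be separated, and the series holds no pair of measured compounds differing in a single place from which a step could be read.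

Compound 3 `Nc1cccc(Nc2c(C(=O)NCc3ccc(F)cc3)nc(Br)c3cccnc23)c1` differs from compound 1 in one place: 3-aminophenyl in place of 4-aminophenyl on a nitrogen on an aromatic ring. Among the compounds with values here, nothing among the measured compounds shows how this exchange bears on this assay. With no guidance of that kind, the expected step of no change at the digits printed from compound 1 to compound 3 (within the scatter) is none beyond the scatter, in either direction. For compound 3 the estimate in this assay is 7000 nM, with a range from 2000 nM to 25000 nM, the width reflecting the absence of any comparable pair.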

Compound 3, half-maximal inhibitory concentration: > 10000 nM
Compound 3 was reported as a limit (the forecaster's own chance of this, stated with the estimate: 10%); middle value at least 1.4-fold (0.15 log units) from the limit.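

In this assay compound 3 gives > 10000 nM, a limit of the assay and not a number. This gives the series its first comparison of compounds differing in one place, 3-aminophenyl in place of 4-aminophenyl on a nitrogen on an aromatic ring, and the step reads an at least 1.4-fold higher number from compound 1 to compound 3 (0.15 log units; that floor lies within the scatter). The floor of that step does not separate the two compounds, so this exchange of amino position shows no firm change at this position, and the reading can go no further than one bound: the limit of > 10000 nM in this assay, at which 1 of the 3 values shown sits.

On these data alone, whether moving the amino group changes this assay at all, and by how much, stays open, as a value for compound 3 inside the measured range would be needed to settle it. Also open, as far as these compounds go, is how a hydroxyl, a methoxy group or a carboxylic acid in place of the amino group on the phenyl ring would read, and whether the same exchange reads alike with chlorine in place of the bromine on the shared core.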